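Stripping the 4-Methylphenyl Group Down to Hydrogen

The source may hold more compounds than are shown below. What is called first, only, known or untested is meant among the compounds shown, and "the series" means these compounds.

Going by the values given here, compound 1 `C=CC(=O)N1C(=O)CC(c2ccc(C)cc2)Sc2ccccc21` gives 94400 nM in a functional assay on HL-60 cells (Homo sapiens) for cytotoxicity, read by CCK-8 assay, with a stated time of 24 h (a higher number here means a weaker inhibitor, a lower number a stronger inhibitor), the lowest of the three numbers measured so far. Compound 2 `C=CC(=O)N1C(=O)CC(c2ccc(C(=O)OC)cc2)Sc2ccccc21` gives 102000 nM, with the step of a 1.1-fold higher number from compound 1 to compound 2 (0.03 log units; within the scatter). Compound 3 `C=CC(=O)N1C(=O)CC(C)Sc2ccccc21` gives 199000 nM, with the step of a 2.1-fold higher number from compound 1 to compound 3 (0.32 log units; beyond the scatter). Compound 4 `C=CC(=O)N1C(=O)CCSc2ccccc21` has not yet been measured; it differs from compound 1 in one place: hydrogen in place of 4-methylphenyl on a saturated ring carbon. Among the compounds with values here, the only measured step that bears on this change is the one in which the 4-methylphenyl group was exchanged for methyl, and there the number rose modestly. Removing the group altogether is expected to act in the same direction, likely a little further. The expected step is a 2.4-fold higher number from compound 1 to compound 4 (0.39 log units; beyond the scatter). Compound 4 is therefore estimated at 230000 nM, within a range from 120000 nM to 450000 nM.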

Compound 4, half-maximal inhibitory concentration: 44800 nM
Estimate against measurement, compound 4: 5.1-fold (0.71 log units) above; measured number outside the range, below it.
By their numbers in this assay, from the lowest: compound 4; then compounds 1, 2 and 3 (each within the scatter of the next, the first and the last beyond it).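

In this assay, shortening the group at this saturated ring carbon next to the ring sulfur does not move the number in one direction: methyl gave a higher number than 4-methylphenyl, yet hydrogen gives a 2.1-fold lower number from compound 1 to compound 4 (0.32 log units; beyond the scatter) and a 4.4-fold lower number from compound 3 to compound 4 (0.65 log units; beyond the scatter). Of the three groups compared at this carbon, hydrogen gives the lowest number and methyl the highest. No available evidence accounts for this reversal.

Going by these compounds, whether an amine, a hydroxyl or a longer chain at this carbon would give a number below that of compound 4 remains open. The compounds shown also leave open how a group other than vinylcarbonyl on the ring nitrogen would behave.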